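Aryl variation on the dienone chain: compound 4

A few compounds are considered here, and "the series" means these few. Any claim that something is new, unique, unknown or untested is made for them only; others in the source may bear on it.

Of the compounds shown here, three sharing one core have been measured in a functional assay on PC-3 cells (Homo sapiens) for cytotoxicity, read by MTT assay, with a stated time of 72 h; a higher number here means a weaker inhibitor, a lower number a stronger inhibitor. Compound 1 `COc1ccc(/C=C/C(=O)/C=C/C2=C(C)CCCC2(C)C)cc1OC` gives 42000 nM. Compound 2 `CC1=C(/C=C/C(=O)/C=C/c2ccc(C(F)(F)F)cc2)C(C)(C)CCC1` gives 12000 nM. Compound 3 `CC1=C(/C=C/C(=O)/C=C/c2ccccc2F)C(C)(C)CCC1` gives 22100 nM. Compound 3 falls between the other two numbers, yet its gap to compound 2 and its gap to compound 1 both lie within the usual scatter, so the three readings cannot be told apart in this assay. Among the measured compounds shown here, no single-point step between measured compounds is available in the set.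

Compound 4 `CC1=C(/C=C/C(=O)/C=C/c2cccc(C)c2)C(C)(C)CCC1` differs from compound 3 in one place: 3-methylphenyl in place of 2-fluorophenyl on a double-bonded chain carbon bound to a double-bonded chain carbon. The three measured aryl variants spread over less than the scatter, and nothing in the set points to the 3-methylphenyl group moving the number one way or the other. The step from compound 3 to compound 4 is therefore expected to be a 1.0-fold lower number from compound 3 to compound 4 (0.00 log units; within the scatter), that is, none beyond the scatter. Compound 4 is estimated at 22000 nM, with a range from 8000 nM to 55000 nM.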

Compound 4, half-maximal inhibitory concentration: 35000 nM
Compound 4: the middle estimate sits 1.6-fold (0.20 log units) below what was measured; measured number inside the range.
By their numbers in this assay, from the lowest: compounds 2, 3, 4 and 1 (each within the scatter of the next, the first and the last beyond it).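

Among the compounds shown here, this is the first single-place step: in this assay, 3-methylphenyl in place of 2-fluorophenyl on a double-bonded chain carbon bound to a double-bonded chain carbon gives a 1.6-fold higher number from compound 3 to compound 4 (0.20 log units; within the scatter). The two readings cannot be told apart, so this exchange of a fluorine-bearing phenyl for a methyl-bearing phenyl, with the same heavy-atom count and no hydrogen-bond donors or acceptors on either group, leaves no resolved mark on the number. No measurement is at hand that could explain the step or its size.

On these data alone, whether this place responds at all to aryl change remains open, since both groups compared here are uncharged phenyl groups. A phenyl bearing an amine or a carboxylic acid, or a longer chain in place of the aryl group, would test the position more sharply.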